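Methylsulfanyl in Place of Fluoro on the Fused Ring

The source may report more compounds than this note shows. Statements on the series, on what has been measured and on what is new or still open speak of the compounds shown alone.

Measured compounds:
compound 1, `CCN(C(=O)c1c(O)c2c(F)cccc2n(C)c1=O)c1ccccc1` — 60%
compound 2, `COc1cccc2c1c(O)c(C(=O)N(C)c1ccccc1Cl)c(=O)n2C` — 50%

Of the compounds shown here, two have been measured in a functional assay on the whole organism for inhibition, with Mus musculus as the target, at a dose of 1 mg/kg by the oral route; on this read-out lower numbers stand for less inhibition and higher numbers for more inhibition at the one dose given (going by the name of the read-out). In this assay compound 1 gives 60%, and compound 2 gives 50%. Compound 1 thus holds the larger of the two numbers, but its gap to compound 2, the nearer of the two, lies within the usual scatter of repeated measurements, so the two compounds cannot be told apart on these data. Going by the values given here, no pair of measured compounds differs in a single place, so no measured step is available to guide an expectation.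

Compound 3, `CCN(C(=O)c1c(O)c2c(SC)cccc2n(C)c1=O)c1ccccc1`, has not yet been measured in this assay. It differs from compound 1 in one place: methylsulfanyl in place of fluoro on an aromatic carbon. Nothing measured here shows what such an exchange does to this read-out. Since compound 1 gives 60%, the expected step in this assay is a number 5 percentage points lower from compound 1 to compound 3 (within the scatter), a change not expected to go beyond the scatter in either direction. Compound 3 is therefore estimated at 55%, within a range from 30% to 80%.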

Compound 3, a percentage reported as inhibition, in the whole organism at one dose (the size of the read-out at that dose, not a potency): 73%
Compound 3: the middle estimate sits 18 percentage points below what was measured; low and high end bracket the measured number.
By their numbers in this assay, from the lowest: compounds 2 and 1 (each within the scatter of the next); then compound 3.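

In this assay, going by these compounds alone, methylsulfanyl in place of fluoro on an aromatic carbon of the six-membered carbon ring gives the first readable single-place step in this set, a number 13 percentage points higher from compound 1 to compound 3 (beyond the scatter). The position, which is part of a fused or bridged system of two rings, therefore accepts a group of two heavy atoms, one carbon and one sulfur, in place of the single fluorine, and the read-out rises rather than falls at the one dose given. The data at hand offer no explanation for this rise.

The compounds shown leave open whether the step comes from the sulfur, from the added methyl or from the larger size of the entering group, and whether a longer chain such as ethylsulfanyl, or an amine such as dimethylamino, would raise or lower the number at this position. Because this read-out gives the size of the effect at one dose and not a potency, they also leave open whether compound 3 would keep its lead over compound 1 at other doses.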